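The compounds below may be only part of what the source reports. "The series", "measured", "known", "first", "only" and "open" are said of these compounds alone.

Measured so far:
- compound 1, `Cc1nn(C)c(Oc2ccc(Cl)cc2)c1/C=N/OCc1ccc(C(F)(F)F)cc1`: 16.4%
- compound 2, `COc1cccc(CO/N=C/c2c(C)nn(C)c2Oc2ccccc2)c1`: 8.4%

In a functional assay on MCF7 cells (Homo sapiens) for antiproliferative activity, tested at 1 uM (a lower number here means less inhibition, a higher number more inhibition at the concentration tested (going by the name of the read-out)), compound 1 gives 16.4%, and compound 2 gives 8.4%. The two numbers lie within the scatter of each other, so neither can be placed above the other; both show weak inhibition at the concentration tested. Within the data shown here, no step between compounds differing in one place is available, and compound 1 and compound 2 differ in more than one place, so the series gives no measured step to lean on.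

Compound 3, `Cc1ccc(CO/N=C/c2c(C)nn(C)c2Oc2ccccc2)cc1`, is not yet measured. It differs from compound 2 as follows: 4-methylphenyl in place of 3-methoxyphenyl on a saturated chain carbon bound to an oxygen on an unsaturated carbon. With only two weak, mutually indistinguishable values in hand, no direction can be argued for this change; the expected step from compound 2 to compound 3 is none beyond the scatter, estimated as a number 2.6 percentage points higher from compound 2 to compound 3 (within the scatter). For compound 3 in this assay the estimate is 11%, with a range from 0% to 25%.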

Compound 3, a percentage reported as inhibition, at one concentration (the size of the read-out at that concentration, not a potency): 38.2%
Compound 3: the middle estimate sits 27.2 percentage points below what was measured, outside the stated range (above it).
By their numbers in this assay, from the lowest: compounds 2 and 1 (each within the scatter of the next); then compound 3.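

At the place on a saturated chain carbon bound to an oxygen on an unsaturated carbon, this assay now gives a first readable step: 4-methylphenyl in place of 3-methoxyphenyl brings a number 29.8 percentage points higher from compound 2 to compound 3 (beyond the scatter). The aryl group at this place therefore matters to this read-out, which compound 1 and compound 2, within the scatter of each other and differing in more than one place, could not show. Nothing at hand bears on what lies behind the step.

On these data alone, the change alters both the substituent and its ring position at once, so it remains open whether the step follows the methyl group or the 4-position, a question that 3-methylphenyl and 4-methoxyphenyl would separate. Also open, as far as these compounds go, is how a 4-aminophenyl or 4-carboxyphenyl group would read at this place.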